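Bromo to Methoxy on the Pendant Phenyl Ring

The source may report more compounds than this note shows. Statements on the series, on what has been measured and on what is new or still open speak of the compounds shown alone.

Compound 1 `Cc1ccccc1-n1nncc1CN1C(=O)C2(C(C#N)=C(N)Oc3c2c2nc4ccccc4nc2c2ccccc32)c2ccccc21` is tested in a functional assay on A549 cells (Homo sapiens) for antiproliferative activity, read by MTT assay, with a stated time of 48 h (a higher number here means a weaker inhibitor, a lower number a stronger inhibitor), and gives > 50000 nM, which is a limit of the assay rather than a number.
Compound 2 `Cc1cccc(-n2nncc2CN2C(=O)C3(C(C#N)=C(N)Oc4c3c3nc5ccccc5nc3c3ccccc43)c3ccccc32)c1` gives 39600 nM in this assay.
Compound 3 `N#CC1=C(N)Oc2c(c3nc4ccccc4nc3c3ccccc23)C12C(=O)N(Cc1cnnn1-c1ccc(Br)cc1)c1ccccc12` gives 44300 nM in this assay.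

Of the two actual numbers, compound 3 carries the higher one, yet its nearest neighbour is compound 2 and a 1.1-fold higher number from compound 2 to compound 3 (0.05 log units; within the scatter) sits within the scatter, so the two cannot be told apart. All three measured compounds share one core and differ only in the group on the aromatic nitrogen. The other steps, an at least 1.2-fold lower number from compound 1 to compound 2 (0.10 log units; that floor lies within the scatter) and an at least 1.1-fold lower number from compound 1 to compound 3 (0.05 log units; that floor lies within the scatter), are also at or within the scatter, so exchanging that group has so far produced no shift that can be trusted.

Compound 4 `COc1ccc(-n2nncc2CN2C(=O)C3(C(C#N)=C(N)Oc4c3c3nc5ccccc5nc3c3ccccc43)c3ccccc32)cc1` takes the next step: methoxy in place of bromo on an aromatic carbon. Among the measured compounds shown here, none of the measured steps exchanges bromo for methoxy, so no step bears directly on this change; the comparisons that exist, each exchanging one substituted phenyl for another, all stayed within the scatter. The expectation is therefore a 1.0-fold lower number from compound 3 to compound 4 (0.00 log units; within the scatter), nothing beyond the scatter. For compound 4 the estimate in this assay is 44000 nM, with a range from 20000 nM to 100000 nM.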

Compound 4, half-maximal inhibitory concentration: > 50000 nM
Compound 4: a limit, no number (the forecaster's own chance of this, stated with the estimate: 40%); middle value at least 1.1-fold (0.05 log units) away from the limit.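

In this assay compound 4 gives > 50000 nM, which is a limit of the assay and not a number. Among the compounds shown, this is the one exchange that keeps the substituent in the same place on the phenyl ring, para to a large group: methoxy brings in a hydrogen-bond acceptor where bromo has none, and the result is an at least 1.1-fold higher number from compound 3 to compound 4 (0.05 log units; that floor lies within the scatter), alongside an at least 1.2-fold higher number from compound 2 to compound 4 (0.10 log units; that floor lies within the scatter), so both floors lie within the scatter and no gain in strength appears from this change. The step from compound 1 to compound 4 cannot be read, since neither compound has an actual number, and the series now presses against the top of the range that can be read: the limit of > 50000 nM in this assay, at which 2 of the 4 values shown sit.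

As far as these compounds go, how far compound 4 truly lies from compound 3 remains unknown, so the size of the effect of methoxy in place of bromo stays open. Also open, from the compounds shown here alone, is whether an amine, a carboxylic acid or a longer chain on this phenyl ring would bring the number clearly down, or whether the shared core keeps every such compound in the same weak range.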